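Swapping the aryl arm of compound 3 for pentan-3-yl

The compounds below may be only part of what the source reports. "The series", "measured", "known", "first", "only" and "open" are said of these compounds alone.

Compound 1 `COc1ccccc1Oc1ccc2c(NCCCNCc3ccco3)ccnc2c1`: 317 10^-6 cm/s
Compound 2 `c1ccc(Oc2ccc3c(NCCCNCc4ccco4)ccnc3c2)cc1`: 317 10^-6 cm/s
Compound 3 `CC(C)(C)c1ccc(-c2ccc3c(NCCCNCc4ccco4)ccnc3c2)cc1`: 237 10^-6 cm/s

In an ADME assay for permeability, using PAMPA, with a stated time of 30 min, at pH 7.4 (a lower number here means that the compound crosses the layer more slowly, a higher number that the compound crosses the layer faster), compound 1 gives 317 10^-6 cm/s, compound 2 gives 317 10^-6 cm/s and compound 3 gives 237 10^-6 cm/s. Compound 3 carries the lowest of the three numbers, but the step of a 1.3-fold lower number from compound 1 to compound 3 (0.13 log units; within the scatter) and the step of a 1.3-fold lower number from compound 2 to compound 3 (0.13 log units; within the scatter) both lie within the scatter, as does the step of no change at the digits printed from compound 1 to compound 2 (within the scatter), so the three compounds are not separated by this assay.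

Compound 4 `CCC(CC)c1ccc2c(NCCCNCc3ccco3)ccnc2c1` differs from compound 3 in one place: pentan-3-yl in place of 4-(tert-butyl)phenyl on an aromatic carbon. Within the data shown here, no measured step removes the aromatic ring of this arm in favour of a chain, so the three steps bear only loosely on it; all of them were within the scatter. The step of a 1.1-fold higher number from compound 3 to compound 4 (0.02 log units; within the scatter) is therefore expected to stay within the scatter, and compound 4 is estimated at 250 10^-6 cm/s, with a range from 130 10^-6 cm/s to 420 10^-6 cm/s.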

Compound 4, apparent permeability: 23 10^-6 cm/s
Estimate against measurement, compound 4: 11-fold (1.04 log units) above; the whole stated range lies above it.
By their numbers in this assay, from the lowest: compound 4; then compounds 3, 1 and 2 (each within the scatter of the next).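

Compounds 1, 2 and 3, with their 2-methoxyphenoxy, phenoxy and 4-(tert-butyl)phenyl arms, were not separated in this assay, but pentan-3-yl at this position breaks from all three (a 10-fold lower number from compound 3 to compound 4 (1.01 log units; beyond the scatter); a 14-fold lower number from compound 2 to compound 4 (1.14 log units; beyond the scatter); a 14-fold lower number from compound 1 to compound 4 (1.14 log units; beyond the scatter)). The position is therefore not indifferent to what it carries: the three arms with an aromatic ring stand together, and the ringless arm stands apart. Nothing shown gives a cause for this drop.

The compounds shown leave open whether the number follows the missing aromatic ring or the smaller arm. A cyclohexyl group or a longer chain such as octyl at this place would separate the two.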